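Adding an Ethyl Group to a Cyanoguanidine: Expected Lipophilicity

The source may report more compounds than this note shows. Statements on the series, on what has been measured and on what is new or still open speak of the compounds shown alone.

Measured so far:
Compound 1, `CCN/C(=N\C#N)NCc1ccc(Cl)nc1`, gives 0.86.
Compound 2, `CN(Cc1ccc(Cl)nc1)/C(N)=N/C#N`, gives 0.71.

Both numbers come from a physicochemical assay for lipophilicity, using the shake flask method, measured as octanol-water partition, at 23 degrees C; on this read-out higher numbers stand for higher lipophilicity and lower numbers for lower lipophilicity. Compound 2 has the lower of the two values, and its nearest neighbour is compound 1, whose number lies higher by an amount that stays within the scatter of repeated measurements, so the two read as essentially alike on this assay.

Compound 3, `CCN/C(=N\C#N)N(C)Cc1ccc(Cl)nc1`, has not yet been measured. It differs from compound 2 in one place: ethyl in place of hydrogen on an amine nitrogen. In plain words, the change is ethyl in place of hydrogen on an amine nitrogen, and cut one bond further out it reads as amino to ethylamino.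

For the measured compounds named here, no measured pair in this set shows this exact change, so the expected size of the step has to be a judgement. For compound 3 the step in this assay is estimated as a number 0.79 log units higher from compound 2 to compound 3 (beyond the scatter), upward and beyond the scatter. The estimated value for compound 3 is therefore 1.5, with a likely range from 1 to 2.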

Compound 3, partition coefficient: 1.02
Beside the measured number, compound 3's estimate is 0.48 log units above it; low and high end bracket the measured number.
By their numbers in this assay, from the lowest: compounds 2, 1 and 3 (each within the scatter of the next, the first and the last beyond it).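

In this assay, for the compounds shown here, ethyl in place of hydrogen on an amine nitrogen, whose other neighbour here is a carbon with a double bond to nitrogen, gives a number 0.31 log units higher from compound 2 to compound 3 (beyond the scatter) and is the only single change in this small set that clears the usual scatter. This shows that this nitrogen can carry an ethyl group with a modest measurable shift, something the two earlier compounds, which read as alike, could not show. The other single change, methyl in place of hydrogen on an amine nitrogen, gives a number 0.16 log units higher from compound 1 to compound 3 (within the scatter) and so leaves that pair reading as alike, while no supporting measurement is available to explain either step.

On these data alone, each change rests on a single pair of compounds, so it remains open whether the ethyl step would look the same on a different core or in a different setting. As far as these compounds go, it also remains open how this nitrogen would read in the same assay with a longer chain such as propyl or butyl, or with a ring such as cyclopropyl or a chain ending in a hydroxyl group.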